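From Acid to Alcohol on a Pyrrolidine Side Chain

A few compounds are considered here, and "the series" means these few. Any claim that something is new, unique, unknown or untested is made for them only; others in the source may bear on it.

Measured so far:
- compound 1 `c1ccc2cc(-c3noc([C@@H]4CCCN4)n3)ccc2c1`: 34500 nM
- compound 2 `O=C(O)CCN1CCC[C@H]1c1nc(-c2ccc3ccccc3c2)no1`: 28400 nM

Both compounds were tested in an assay on HepG2 cells for antagonist activity at Bile acid receptor (Homo sapiens), read by a luciferase reporter; a higher number here means a weaker inhibitor, a lower number a stronger inhibitor. Compound 1 gives 34500 nM and compound 2 gives 28400 nM. Compound 2 has the lower of the two numbers, but the step of a 1.2-fold lower number from compound 1 to compound 2 (0.08 log units; within the scatter), so on the numbers shown the two compounds cannot be told apart.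

Compound 3 `OCCCN1CCC[C@H]1c1nc(-c2ccc3ccccc3c2)no1` has not yet been measured. It differs from compound 2 in one place: hydroxymethyl in place of carboxy on a saturated chain carbon, two bonds along the chain from an amine nitrogen in a ring. For the measured compounds named here, the only measured step that bears on this part of the molecule is a 1.2-fold lower number from compound 1 to compound 2 (0.08 log units; within the scatter), where the whole 2-carboxyethyl chain was added to the amine nitrogen without a change beyond the scatter. Since adding the carboxy-bearing chain did not move the number, swapping the carboxy for a hydroxymethyl at its end is expected to leave the number much where it is, with no step beyond the scatter in either direction. The estimated step is a 1.1-fold higher number from compound 2 to compound 3 (0.02 log units; within the scatter). Compound 3 is therefore expected to give about 30000 nM, within a range from 12000 nM to 80000 nM.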

Compound 3, half-maximal inhibitory concentration: 20500 nM
The estimate for compound 3 lay 1.5-fold (0.17 log units) above the measured number, and the stated range covers the measured number.
By their numbers in this assay, from the lowest: compounds 3, 2 and 1 (each within the scatter of the next).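

In this assay putting hydroxymethyl in place of carboxy on a saturated chain carbon, two bonds along the chain from an amine nitrogen in a ring, gives a 1.4-fold lower number from compound 2 to compound 3 (0.14 log units; within the scatter) and so shows that the carboxy group at the end of this chain is not needed to keep the number at the level of compound 2. Compared with the compound that carries no chain, 3-hydroxypropyl in place of hydrogen on the amine nitrogen in a ring gives a 1.7-fold lower number from compound 1 to compound 3 (0.23 log units; within the scatter) and so shows that neither chain end tried so far separates from plain hydrogen at this nitrogen. No measurement here says why these changes leave the number within the scatter.

The compounds shown leave open whether any group on this nitrogen can move the number beyond the scatter in either direction. An amine or an amide at the end of the chain, or a longer chain ending in a carboxylic acid or an alcohol, would each test this further.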